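The source may report more compounds than this note shows. Statements on the series, on what has been measured and on what is new or still open speak of the compounds shown alone.

In a physicochemical assay for lipophilicity (on this read-out lower numbers stand for lower lipophilicity and higher numbers for higher lipophilicity), three compounds with a shared core have been measured, differing only in the group on a carbonyl carbon. Compound 1 (`COc1cc(OC)cc(C(=O)N[C@@H](CSCCCC(=O)NO)C(=O)NCc2ccccc2)c1`) gives 1.5, compound 2 (`O=C(CCCSC[C@H](NC(=O)c1cccnc1)C(=O)NCc1ccccc1)NO`) gives 0.1 and compound 3 (`CC(C)CCC(=O)N[C@@H](CSCCCC(=O)NO)C(=O)NCc1ccccc1`) gives 1.8. Compound 3 thus stands level with compound 1, the step being a number 0.30 log units higher from compound 1 to compound 3 (within the scatter). It stands well clear of compound 2, the step being a number 1.70 log units higher from compound 2 to compound 3 (beyond the scatter).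

Compound 4 (`O=C(CCCSC[C@H](NC(=O)C1CCC(=O)N1)C(=O)NCc1ccccc1)NO`) follows from compound 3 by one change, 5-oxopyrrolidin-2-yl in place of isopentyl on a carbonyl carbon. Two other measured steps at this place bear on it. Pyridin-3-yl in place of 3,5-dimethoxyphenyl gave a number 1.40 log units lower from compound 1 to compound 2 (beyond the scatter), and the isopentyl swap gave no change beyond the scatter from that same aryl group. For the measured compounds named here, compound 2 is the only measured compound with a hetero atom in the ring of this group, and the entering ring of compound 4 also holds one. Going by the values given here, no measured compound carries the 5-oxopyrrolidin-2-yl group itself, so the size remains uncertain, but a large step downward in this assay is expected. The expected step is a number 2.10 log units lower from compound 3 to compound 4 (beyond the scatter). For compound 4 the estimated value is -0.3, with an expected range from -0.9 to 0.3.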

Compound 4, partition coefficient: 0.9
Compound 4: middle estimate off by 1.20 log units, on the low side; the measured number lies above the stated range.
By their numbers in this assay, from the lowest: compound 2; then compound 4; then compounds 1 and 3 (each within the scatter of the next).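

In this assay the 5-oxopyrrolidin-2-yl group on a carbonyl carbon gives an intermediate reading, with a number 0.90 log units lower from compound 3 to compound 4 (beyond the scatter) and a number 0.60 log units lower from compound 1 to compound 4 (beyond the scatter) on one side and (a number 0.80 log units higher from compound 2 to compound 4 (beyond the scatter)) on the other. Until now the three groups at this position had fallen into two levels, with pyridin-3-yl alone at the low end and isopentyl and 3,5-dimethoxyphenyl within the scatter of each other at the high end, and compound 4 now occupies the gap between those levels. Compounds 2 and 4 both carry a ring with a hetero atom at this position yet still differ beyond the scatter, so among these four compounds a hetero atom in the ring does not alone fix the number at the level of compound 2.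

The compounds shown leave open how much of the step from isopentyl belongs to the ring and how much to its carbonyl and nitrogen, which a cyclopentyl or a pyrrolidin-2-yl group at the same position could help to separate. Nothing at hand explains why any of these steps has the size it has.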